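The source may hold more compounds than are shown below. What is called first, only, known or untested is meant among the compounds shown, and "the series" means these compounds.

Compound 2, `COc1ccc2c(=O)c(/C=C/C(=O)NCc3cccc(F)c3)coc2c1`, is one of three close analogues tested in a functional assay on Huh-7 cells (Homo sapiens) for inhibition, read by MTT assay, with a stated time of 48 h; a lower number here means a stronger inhibitor, a higher number a weaker inhibitor. In this assay compound 2 gives 10100 nM, the lowest of the two numbers recorded. Compound 1, `COc1ccc2c(=O)c(/C=C/C(=O)Nc3cccc(C)c3)coc2c1`, gives 15500 nM in this assay. Among the measured compounds shown here, compound 3, `Cc1ccc(CNC(=O)/C=C/c2coc3cc(O)ccc3c2=O)cc1`, reaches only (the limit of > 100000 nM in this assay, at which 1 of the 3 values shown sits), a limit of this assay rather than a number, so compound 3 gives > 100000 nM in this assay and sets no measured step.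

For the measured compounds named here, the one measured step, a 1.5-fold lower number from compound 1 to compound 2 (0.19 log units; within the scatter), shows that exchanging an aryl amide for a benzyl amide on this core moved the number within the scatter. Compound 4, `COc1ccc2c(=O)c(/C=C/C(=O)Nc3ccc(F)cc3)coc2c1`, differs from compound 2 by 4-fluorophenyl in place of 3-fluorobenzyl on an amide-type nitrogen. This change largely reverses the measured step, returning to an aryl amide while keeping a fluorine, so compound 4 is expected to sit close to compound 2 and compound 1, with no step beyond the scatter in this assay: the expected step is a 1.4-fold higher number from compound 2 to compound 4 (0.14 log units; within the scatter). Compound 4 is therefore estimated at 14000 nM in this assay, with a range from 5000 nM to 40000 nM.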

Compound 4, half-maximal inhibitory concentration: 33900 nM
The estimate for compound 4 lay 2.4-fold (0.38 log units) below the measured number, within the range that was stated.
By their numbers in this assay, from the lowest: compounds 2 and 1 (each within the scatter of the next); then compound 4. At a limit, above all of these: compound 3.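

In this assay the group on the amide-type nitrogen now makes a readable difference, with a 3.4-fold higher number from compound 2 to compound 4 (0.53 log units; beyond the scatter) on exchanging 3-fluorobenzyl for 4-fluorophenyl and a 2.2-fold higher number from compound 1 to compound 4 (0.34 log units; beyond the scatter) on exchanging 3-methylphenyl for 4-fluorophenyl. The earlier exchange of 3-methylphenyl for 3-fluorobenzyl, a 1.5-fold lower number from compound 1 to compound 2 (0.19 log units; within the scatter) here, had given no step beyond the scatter, whereas both new steps, though modest, run in the same direction, so this position is not indifferent to the group it carries and 4-fluorophenyl has the highest measured number of the three groups. Nothing among the data shown accounts for these steps.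

Compound 4 differs from compound 2 both in the carbon that joins the ring to the nitrogen and in the place of the fluorine, so a 3-fluorophenyl or a 4-fluorobenzyl group on the same nitrogen would be needed to tell these two changes apart. From the compounds shown here alone, how a ring carrying an amine or a carboxylic acid, or a longer chain between the ring and the nitrogen, would behave at this position also remains open.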